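Diethoxymethyl on compound 1: a small step expected

The source may hold more compounds than are shown below. What is called first, only, known or untested is meant among the compounds shown, and "the series" means these compounds.

In a functional assay on LNCaP cells (Homo sapiens) for cytotoxicity, read by MTT assay, with a stated time of 72 h (on this read-out lower numbers stand for stronger inhibition and higher numbers for weaker inhibition), compound 1 `CC1=C(/C=C/C(=O)/C=C/c2ccccc2)C(C)(C)CCC1O` gives 5800 nM and compound 2 `CC1=C(/C=C/C(=O)/C=C/c2ccc(C(F)(F)F)cc2)C(C)(C)CCC1O` gives 3000 nM, which places the two within the scatter of each other. Compound 3 `CCOC(OCC)c1cccc(/C=C/C(=O)/C=C/C2=C(C)C(O)CCC2(C)C)c1` is still unmeasured and carries diethoxymethyl in place of hydrogen on an aromatic carbon, diethoxymethyl in place of hydrogen on an aromatic carbon. Going by the values given here, the one measured step bearing on this change, with trifluoromethyl in place of hydrogen on an aromatic carbon, is a 1.9-fold lower number from compound 1 to compound 2 (0.29 log units; within the scatter). That step stays within the scatter and involves a different group, so no step beyond the scatter is expected in this assay. The estimated change is a 1.3-fold lower number from compound 1 to compound 3 (0.11 log units; within the scatter). For compound 3, the estimated value is 4500 nM, with an expected range of 1800 nM to 11000 nM.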

Compound 3, half-maximal inhibitory concentration: 1800 nM
Estimate against measurement, compound 3: 2.5-fold (0.40 log units) above, within the range that was stated.
By their numbers in this assay, from the lowest: compounds 3, 2 and 1 (each within the scatter of the next, the first and the last beyond it).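

In this assay the diethoxymethyl change gives a 3.2-fold lower number from compound 1 to compound 3 (0.51 log units; beyond the scatter), so a group placed on the aromatic ring of compound 1 can move the number beyond the scatter, although only modestly. The trifluoromethyl change, with a 1.9-fold lower number from compound 1 to compound 2 (0.29 log units; within the scatter), had not shown this. No measurement shown here bears on the reason for the step. Going by these compounds, it remains open whether the effect belongs to diethoxymethyl itself or would also appear with a methoxy group or an amine at this same place on the ring.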